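The compounds below may be only part of what the source reports. "The series", "measured", "known", "first", "only" and "open" are said of these compounds alone.

In an ADME assay on the whole organism for cytotoxicity, with Artemia salina as the target, with a stated time of 24 h (on this read-out lower numbers stand for an effect already at smaller amounts and higher numbers for an effect only at larger amounts of compound), the three measured compounds stand as follows:
compound 1 `Cc1ccc(/C=C/C(=O)c2ccccc2NC(=O)NS(=O)(=O)c2ccc(C)cc2)cc1` gives 15.3 ug/mL;
compound 2 `COc1cccc(/C=C/C(=O)c2ccccc2NC(=O)NS(=O)(=O)c2ccc(C)cc2)c1` gives 23.2 ug/mL;
compound 3 `Cc1ccc(S(=O)(=O)NC(=O)Nc2ccccc2C(=O)/C=C/c2ccc(Cl)cc2)cc1` gives 6.92 ug/mL.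

Compound 2 shows the highest number of the three; compound 1 lies nearest, with a 1.5-fold higher number from compound 1 to compound 2 (0.18 log units; within the scatter), and compound 3 furthest, with a 3.4-fold lower number from compound 2 to compound 3 (0.53 log units; beyond the scatter). Compound 4 `C=CCOc1ccc(/C=C/C(=O)c2ccccc2NC(=O)NS(=O)(=O)c2ccc(C)cc2)cc1` arises from compound 2 by the change (4-(allyloxy)phenyl in place of 3-methoxyphenyl on a double-bonded chain carbon bound to a double-bonded chain carbon). Two steps at this place bear on the expectation: a 1.5-fold higher number from compound 1 to compound 2 (0.18 log units; within the scatter), which stayed within the scatter, and a 3.4-fold lower number from compound 2 to compound 3 (0.53 log units; beyond the scatter), a modest drop. Compound 4 is therefore expected to sit somewhat lower than compound 2, with an estimated step of a 1.9-fold lower number from compound 2 to compound 4 (0.29 log units; within the scatter). Compound 4 is estimated at 12 ug/mL, with a range from 5 ug/mL to 28 ug/mL.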

Compound 4, concentration for half-maximal effect: 6.11 ug/mL
Beside the measured number, compound 4's estimate is 2.0-fold (0.29 log units) above it; low and high end bracket the measured number.
By their numbers in this assay, from the lowest: compounds 4 and 3 (each within the scatter of the next); then compounds 1 and 2 (each within the scatter of the next).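

In this assay, this place on a double-bonded chain carbon bound to a double-bonded chain carbon tolerates 4-(allyloxy)phenyl, which carries an oxygen-linked chain with a double bond, and the number falls with a 3.8-fold lower number from compound 2 to compound 4 (0.58 log units; beyond the scatter) and with a 2.5-fold lower number from compound 1 to compound 4 (0.40 log units; beyond the scatter). Lower numbers here are thus not confined to the chloro group, since allyloxy in place of chloro on an aromatic carbon gives a 1.1-fold lower number from compound 3 to compound 4 (0.05 log units; within the scatter). No measurement at hand accounts for these steps.

The compounds shown leave open whether the allyl part or the ether oxygen matters for the lower number. They also leave open how an amine, a carboxylic acid or a longer alkoxy chain would read at this place.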